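The compounds below may be only part of what the source reports. "The series", "measured", "known", "first", "only" and "open" are said of these compounds alone.

Compound 1, `COC(=O)C1=CN(C)C(=O)[C@@H]2C(CN3CCN(Cc4ccc(C(F)(F)F)cc4)CC3)=CC[C@H]12`, gives 80.9% in a functional assay on Cortical neurone cells (Rattus norvegicus, strain Sprague-Dawley), read by MTT assay, with stated times of 24 h and 2 h, tested at 10 uM; a lower number here means a weaker effect, a higher number a stronger effect of the compound at the concentration tested. Among the three measured compounds it stands second of the three numbers: compound 3, `COC(=O)C1=CNC(=O)[C@@H]2C(CO)=CC[C@H]12`, gives 79.3% and is nearest to it, while compound 2, `COC(=O)C1=CN(C(C)C)C(=O)[C@@H]2C(CN3CCN(Cc4ccc(C(F)(F)F)cc4)CC3)=CC[C@H]12`, gives 85.7% and is furthest from it, and both gaps lie within the scatter. Among the measured compounds shown here, the only measured step that changes one place, a number 4.8 percentage points higher from compound 1 to compound 2 (within the scatter), alters the substituent on the amide-type nitrogen in the ring and does not touch the benzyl group. Compound 4, `COC(=O)C1=CN(C)C(=O)[C@@H]2C(CN3CCN(Cc4cccc(C(F)(F)F)c4)CC3)=CC[C@H]12`, differs from compound 1 by 3-(trifluoromethyl)phenyl in place of 4-(trifluoromethyl)phenyl on a saturated chain carbon bound to an amine nitrogen in a ring. For the measured compounds named here, no measured step bears on this change, so a step within the scatter is expected, a number 0.9 percentage points lower from compound 1 to compound 4 (within the scatter). Compound 4 is therefore estimated at 80%, with a range from 68% to 90%.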

Compound 4, a percentage reported as activity, at one concentration (the size of the read-out at that concentration, not a potency): 80.3%
Estimate against measurement, compound 4: 0.3 percentage points below; the measured number falls inside the stated range.
By their numbers in this assay, from the lowest: compounds 3, 4, 1 and 2 (each within the scatter of the next).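

In this assay, 3-(trifluoromethyl)phenyl in place of 4-(trifluoromethyl)phenyl on a saturated chain carbon bound to an amine nitrogen in a ring gives a number 0.6 percentage points lower from compound 1 to compound 4 (within the scatter). This is the only step shown at the benzyl group, and the read-out does not separate these two groups. Nothing shown speaks to the reason for this result. On these data alone, it remains open whether an unsubstituted phenyl, a methoxyphenyl or a pyridine ring at this place would read differently. Also open, as far as these compounds go, is whether the same replacement gives a similar step with isopropyl on the amide-type nitrogen.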